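The source may report more compounds than this note shows. Statements on the series, on what has been measured and on what is new or still open speak of the compounds shown alone.

In a functional assay on cells (Erythrocyte, Rattus norvegicus) for inhibition, read by hemolysis, with a stated time of 1 h (on this read-out lower numbers stand for stronger inhibition and higher numbers for weaker inhibition), two compounds built on a shared core have been measured so far. Compound 1 `COc1cc(OC)c(OC)cc1/C=C/C(=O)c1cc(Cl)ccc1O` gives 2.23 ug/mL, and compound 2 `COc1cc(OC)c(OC)cc1/C=C/C(=O)c1ccc(C)cc1` gives 2.24 ug/mL, so compound 2 stands level with compound 1 within the scatter. Compound 3 `COc1cc(OC)c(OC)cc1/C=C/C(=O)c1ccc(O)cc1` changes compound 2 at a single place, with hydroxy in place of methyl on an aromatic carbon, or 4-methylphenyl to 4-hydroxyphenyl: hydroxy in place of methyl on an aromatic carbon. Among the measured compounds shown here, only one measured step bears on this change: a 1.0-fold higher number from compound 1 to compound 2 (0.00 log units; within the scatter), which swaps 5-chloro-2-hydroxyphenyl for 4-methylphenyl on a carbonyl carbon. That larger exchange at the same ring left the number within the scatter, and it points in neither direction. No step beyond the scatter is therefore expected in this assay, and the expected step is a 1.0-fold higher number from compound 2 to compound 3 (0.01 log units; within the scatter). Compound 3 is estimated at 2.3 ug/mL, with an expected range from 1.1 ug/mL to 4.8 ug/mL.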

Compound 3, half-maximal inhibitory concentration: 2.29 ug/mL
Compound 3: middle estimate off by 1.0-fold (0.00 log units), on the high side; low and high end bracket the measured number.
By their numbers in this assay, from the lowest: compounds 1, 2 and 3 (each within the scatter of the next).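

In this assay, hydroxy brings to this aromatic carbon, para to a large group, a hydrogen-bond donor and acceptor that methyl lacks, yet the direct exchange gives only a 1.0-fold higher number from compound 2 to compound 3 (0.01 log units; within the scatter), so this single-atom swap leaves the number level. The wider exchange of 5-chloro-2-hydroxyphenyl for 4-hydroxyphenyl on the carbonyl carbon gives a 1.0-fold higher number from compound 1 to compound 3 (0.01 log units; within the scatter), which means that all three aromatic groups tried at this end of the molecule read alike here. No measurement at hand explains why these exchanges leave the number level. As far as these compounds go, it remains open whether an amine, a carboxylic acid or a longer alkyl chain at the same position would move the number beyond the scatter. From the compounds shown here alone, whether changes elsewhere on the shared core would do so also remains open.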